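Second Chloro on Two Isomeric Purine-like Cores

The compounds below may be only part of what the source reports. "The series", "measured", "known", "first", "only" and "open" are said of these compounds alone.

Compound 1 `ClCc1ccccc1Cn1cnc2c(Cl)nc(Cl)nc21`: 3470 nM
Compound 2 `ClCc1ccccc1Cn1cnc2c(Cl)ncnc21`: 38000 nM
Compound 3 `ClCc1cccc(Cn2cnc3ncnc(Cl)c32)c1`: 4070 nM

In a functional assay on 786-0 cells (Homo sapiens) for cytotoxicity, read by sulforhodamine B assay, with a stated time of 48 h (a lower number here means a stronger inhibitor of growth, a higher number a weaker inhibitor of growth), compound 2 gives 38000 nM and compound 1 gives 3470 nM. The change from compound 2 to compound 1 is chloro in place of hydrogen on an aromatic carbon and it produced an 11-fold lower number from compound 2 to compound 1 (1.04 log units; beyond the scatter). Compound 3 shares its atoms with compound 2, joined differently; the difference between the two cores is not broken down here. In this assay compound 3 gives 4070 nM, close to compound 1. Compound 4 `ClCc1cccc(Cn2cnc3nc(Cl)nc(Cl)c32)c1` has not yet been measured. It differs from compound 3 by chloro in place of hydrogen on an aromatic carbon, the same kind of change as that from compound 2 to compound 1, with the place described in identical words. Compound 4 is expected to show a 10-fold lower number from compound 3 to compound 4 (1.01 log units; beyond the scatter), resting on an 11-fold lower number from compound 2 to compound 1 (1.04 log units; beyond the scatter). Compound 4 is therefore estimated at 400 nM, between 150 nM and 1500 nM.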

Compound 4, concentration for total growth inhibition: 2880 nM
Compound 4: middle estimate off by 7.2-fold (0.86 log units), on the low side, outside the stated range (above it).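

In this assay, chloro in place of hydrogen on an aromatic carbon gives a 1.4-fold lower number from compound 3 to compound 4 (0.15 log units; within the scatter), so on this core the change leaves no readable difference. The size of the step did not carry over from one core to the other: the same change on two cores in this assay, an 11-fold lower number (1.04 log units; beyond the scatter) from compound 2 to compound 1 and a 1.4-fold lower number (0.15 log units; within the scatter) from compound 3 to compound 4, 7.7-fold (0.89 log units) apart, beyond the scatter of two such steps This shows that, across these two pairs, the effect of the change depends on the core, but it does not show which difference between the two cores is responsible, and two pairs set no rule for the wider series.

The compounds shown leave open whether an amine or a methoxy group, placed between the two ring nitrogen atoms, would also differ between the two cores. From the compounds shown here alone, whether a bromo group there would follow the chloro on either core also remains open.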